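A few compounds are considered here, and "the series" means these few. Any claim that something is new, unique, unknown or untested is made for them only; others in the source may bear on it.

Measured compounds:
Compound 1, `O=C(O)C(Sc1nc(Cl)cc(Nc2cccc(Cl)c2)n1)c1cccc2ccccc12`, gives 700 nM in an assay on isolated protein for inhibition of Polyunsaturated fatty acid 5-lipoxygenase (Homo sapiens); a higher number here means a weaker inhibitor, a lower number a stronger inhibitor.
Compound 2, `CCCCNc1cc(Cl)nc(SC(C(=O)O)c2cccc3ccccc23)n1`, gives 2400 nM.
Compound 3, `O=C(O)C(Sc1nc(Cl)cc(Nc2ccc(C3CCCCC3)cc2)n1)c1cccc2ccccc12`, gives 400 nM.

Among these three numbers compound 1 stands second highest. Its nearest neighbour is compound 3, whose number lies within the scatter of compound 1, so no order between the two can be read. Compound 2 lies further off: a 3.4-fold higher number from compound 1 to compound 2 (0.54 log units; beyond the scatter), a modest step beyond the scatter.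

Compound 4, `O=C(O)C(Sc1nc(Cl)cc(NCCCc2ccccc2)n1)c1cccc2ccccc12`, differs from compound 1 in one place: 3-phenylpropyl in place of 3-chlorophenyl on a nitrogen on an aromatic ring. Among the measured compounds shown here, only the step from compound 1 to compound 2 bears on this change, since there too a chain replaced the 3-chlorophenyl on the same nitrogen, and it gave a modest rise in the number. The entering 3-phenylpropyl is likewise a chain, yet it carries an aromatic ring, so the expected rise is smaller than that seen for compound 2 and may not clear the scatter. The estimated step is a 1.9-fold higher number from compound 1 to compound 4 (0.27 log units; within the scatter). Compound 4 is therefore expected to give about 1300 nM, within a range from 600 nM to 3000 nM.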

Compound 4, half-maximal inhibitory concentration: 1800 nM
Beside the measured number, compound 4's estimate is 1.4-fold (0.14 log units) below it, and the stated range covers the measured number.
By their numbers in this assay, from the lowest: compounds 3 and 1 (each within the scatter of the next); then compounds 4 and 2 (each within the scatter of the next).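

In this assay, the 3-phenylpropyl group on the nitrogen gives a 2.6-fold higher number from compound 1 to compound 4 (0.41 log units; beyond the scatter), so the rise seen with butyl in compound 2 also appears with a chain that carries a six-membered aromatic ring of carbon only. Phenyl in place of methyl on the chain gives a 1.3-fold lower number from compound 2 to compound 4 (0.12 log units; within the scatter), so compound 4 and compound 2 cannot be ordered, and keeping an aromatic ring at the end of the chain does not bring the number back to that of compound 1. Nothing available gives a reason for these differences.

The step from compound 1 to compound 4 changes both the chlorine and the link between ring and nitrogen, so the two contributions cannot be separated. Plain phenyl, benzyl or 2-phenylethyl on the same nitrogen would bear on this, and how an amine at the end of the chain would read remains open.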